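The source may hold more compounds than are shown below. What is called first, only, known or untested is meant among the compounds shown, and "the series" means these compounds.

Compound 1 `COc1cccc([C@@H]2[C@H](Oc3ccccc3)C(=O)N2c2cc(OC)c(OC)c(OC)c2)c1`: 171000 nM
Compound 2 `COc1ccc([C@@H]2[C@H](Oc3ccccc3)C(=O)N2c2cc(OC)c(OC)c(OC)c2)cc1[N+](=O)[O-]`: 69000 nM
Compound 3 `COc1cc(N2C(=O)[C@@H](Oc3ccccc3)[C@H]2c2cc(O)c(OC)c([N+](=O)[O-])c2)cc(OC)c1OC`: 69000 nM

These three values come from a functional assay on MCF7 cells (Homo sapiens) for antiproliferative activity, read by MTT assay, with stated times of 24 h and 72 h; on this read-out higher numbers stand for weaker inhibition and lower numbers for stronger inhibition. Compound 3 is level with compound 2 at the digits shown, and together they hold the lowest of the three numbers, while compound 1 stands clearly higher.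

The next compound is compound 4 `COc1cc(N)c([C@@H]2[C@H](Oc3ccccc3)C(=O)N2c2cc(OC)c(OC)c(OC)c2)cc1O`. It keeps the 3,4,5-trimethoxyphenyl and phenoxy groups of compound 3 but carries a different aromatic group on a saturated ring carbon of the four-membered non-aromatic ring with 1 nitrogen. The change is a group of 10 heavy atoms (7 carbon, 1 nitrogen, 2 oxygen; one six-membered aromatic ring of carbon only) in place of a group of 12 heavy atoms (7 carbon, 1 nitrogen, 4 oxygen; one six-membered aromatic ring of carbon only), on a saturated ring carbon.

Going by the values given here, no measured pair makes this exact exchange, so the evidence is indirect. Two changes at the same ring carbon gave modest steps, a 2.5-fold lower number from compound 1 to compound 2 (0.39 log units; beyond the scatter) and a 2.5-fold lower number from compound 1 to compound 3 (0.39 log units; beyond the scatter). Adding a hydroxy group made no difference, no change at the digits printed from compound 2 to compound 3 (within the scatter). On that evidence, a large shift in this assay is not the expected outcome, although three compounds are a thin basis and the new group differs more than those before it. A small move towards a lower number is expected, with either direction remaining possible. The expected step is a 1.7-fold lower number from compound 3 to compound 4 (0.24 log units; within the scatter). For compound 4 the estimated value is 40000 nM, within an expected range of 5000 nM to 150000 nM.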

Compound 4, half-maximal inhibitory concentration: 20000 nM
Estimate against measurement, compound 4: 2.0-fold (0.30 log units) above; the measured number falls inside the stated range.
By their numbers in this assay, from the lowest: compound 4; then compounds 2 and 3 (each within the scatter of the next); then compound 1.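

In this assay, replacing the nitro-bearing aromatic group on this saturated ring carbon gives a clear gain for the first time among these analogues, with a 3.5-fold lower number from compound 3 to compound 4 (0.54 log units; beyond the scatter) and a 3.5-fold lower number from compound 2 to compound 4 (0.54 log units; beyond the scatter). Losing the nitro group cannot be the whole story, since compound 1 also lacks it yet sits at the other end of the series, and the widest gap so far is an 8.6-fold lower number from compound 1 to compound 4 (0.93 log units; beyond the scatter); the aromatic group at this carbon can therefore move the number in either direction, depending on what else it carries. Nothing measured here explains why the group in compound 4 gives the lower number.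

Because compound 4 differs from compound 3 by several substituents on this one aromatic group, the compounds shown cannot say whether the amino group, the absence of the nitro group or their combination with the hydroxy group accounts for the step. From the compounds shown here alone, it also remains open how this carbon would respond to an aromatic group bearing a chlorine atom or a carboxylic acid, and whether a longer chain in place of the phenoxy group would keep the number this low.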